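The source may hold more compounds than are shown below. What is called first, only, known or untested is meant among the compounds shown, and "the series" means these compounds.

Measured so far:
- compound 1, `O=C(CCSc1nc2cc(Cl)ccc2o1)N1CCC1`: 3.7 mL/min/g
- compound 2, `O=C(CCSc1nc2ncccc2o1)N1CCCC1`: 0.7 mL/min/g
- compound 3, `O=C(CCSc1nc2cc(Cl)ccc2s1)N1CCCC1`: 15 mL/min/g

Three compounds have been run through an ADME assay on microsomes from liver (Homo sapiens) for metabolic stability, read by LC-MS, using NADPH, with a stated time of 45 min, tested at 0.5 uM; a lower number here means slower removal, a higher number faster removal of the compound. Compound 1, built as `O=C(CCSc1nc2cc(Cl)ccc2o1)N1CCC1`, gives 3.7 mL/min/g, the second highest of the three numbers. The nearest neighbour is compound 3, whose value of 15 mL/min/g lies higher by more than the usual scatter of repeated measurements. Furthest away is compound 2, whose value of 0.7 mL/min/g lies lower than that of compound 1, again beyond the scatter. Both of those compounds differ from compound 1 in more than one place, so nothing is counted as a single step between them; their numbers are simply what they are.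

The new compound 4, `CN(C)C(=O)CCSc1nc2cc(Cl)ccc2o1`, has not yet been measured in this assay. It differs from compound 1 in one place:

dimethylamino in place of azetidin-1-yl on a carbonyl carbon

The four-membered ring is swapped for an open pair of methyl groups on the same nitrogen, and the rest of the structure is kept. Within the data shown here, with no measured pair showing this exact swap, the expectation is that the step of a 1.1-fold lower number from compound 1 to compound 4 (0.02 log units; within the scatter) stays within the scatter, with no clear direction. Compound 4 is therefore estimated at 3.5 mL/min/g, with a likely range from 1.5 mL/min/g to 8 mL/min/g.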

Compound 4, intrinsic clearance in a liver preparation (reported as CLH), per the amount of preparation that the assay uses: 2.7 mL/min/g
Compound 4: middle estimate off by 1.3-fold (0.11 log units), on the high side, within the range that was stated.
By their numbers in this assay, from the lowest: compound 2; then compounds 4 and 1 (each within the scatter of the next); then compound 3.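

In this assay, among these compounds, the swap of azetidin-1-yl for dimethylamino on the carbonyl carbon is the first single change that can be read, and it gives a 1.4-fold lower number from compound 1 to compound 4 (0.14 log units; within the scatter) with no shift beyond the scatter. At this place, then, the four-membered ring can be opened into two separate methyl groups on the same nitrogen without a clear change in the number. No measurement shown here explains this result.

As far as these compounds go, it remains open whether this place would stay as unresponsive with groups further from these two, such as a piperidine ring, a morpholine ring or a plain amide carrying a hydrogen on its nitrogen. From the compounds shown here alone, it is also open whether the same swap would behave alike on another core, as it is seen here only on the core of compound 1.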